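Side chain swap in the series: compound 2 to compound 3

The compounds below may be only part of what the source reports. "The series", "measured", "known", "first", "only" and "open" are said of these compounds alone.

The series is read in a functional assay (blood) for inhibition, with Homo sapiens as the target; a lower number here means a stronger inhibitor, a higher number a weaker inhibitor. Compound 1 `OC1O[C@H](CO/N=C2\CCc3cc(Sc4cc(F)cc(C5CCOCC5)c4)ccc32)[C@H](O)[C@H](O)[C@H]1O` reports > 2500 nM, which is a limit of the assay and not a number. Within the data shown here, compound 2 `CCOC(=O)c1csc(CO/N=C(\C)c2ccc(Sc3cc(F)cc(C4CCOCC4)c3)cc2)n1` gives 150 nM, the only true number so far, and it is therefore the single reference point for what follows.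

Compound 3 `C/C(=N\OCCSc1nnnn1C)c1ccc(Sc2cc(F)cc(C3CCOCC3)c2)cc1` has not yet been measured. The change from compound 2 is ((1-methyl-1H-tetrazol-5-yl)sulfanyl)methyl in place of 4-(ethoxycarbonyl)-1,3-thiazol-2-yl on a saturated chain carbon bound to an oxygen on an unsaturated carbon. In words, ((1-methyl-1H-tetrazol-5-yl)sulfanyl)methyl takes the place of 4-(ethoxycarbonyl)-1,3-thiazol-2-yl on a saturated chain carbon bound to an oxygen on an unsaturated carbon.

Among the measured compounds shown here, no measured pair isolates this side chain, so the size of the step cannot be read from the data. A modest weakening in this assay is the working expectation, anchored only on compound 2 at 150 nM, with wide margins on both sides. The estimated step is a 2.0-fold higher number from compound 2 to compound 3 (0.30 log units; within the scatter). Compound 3 is expected at 300 nM, with an estimated range of 90 nM to 1100 nM.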

Compound 3, half-maximal inhibitory concentration: 120 nM
Compound 3: the middle estimate sits 2.5-fold (0.40 log units) above what was measured, within the range that was stated.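

Among these compounds, this is the first pair that isolates the side chain. In this assay, ((1-methyl-1H-tetrazol-5-yl)sulfanyl)methyl in place of 4-(ethoxycarbonyl)-1,3-thiazol-2-yl on a saturated chain carbon bound to an oxygen on an unsaturated carbon reads as a 1.3-fold lower number from compound 2 to compound 3 (0.10 log units; within the scatter), so the two compounds cannot be told apart. For this one pair, the place accepts a different five-membered aromatic ring, with 4 rather than 2 hetero atoms, and the ethoxycarbonyl group is not required for a value at this level. Only compound 1 carries a limit of the assay and not a number, so this comparison rests on true numbers at both ends: the limit of > 2500 nM in this assay, at which 1 of the 3 values shown sits.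

From the compounds shown here alone, how a plain longer alkyl chain, a primary amine or a carboxylic acid would read at this place stays open, as does whether a five-membered aromatic ring is needed there at all. A single pair also leaves open whether the same reading would hold with any other change elsewhere in the molecule.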